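Adding a Benzyl Ester to the Methyl Compound

The source may hold more compounds than are shown below. What is called first, only, known or untested is meant among the compounds shown, and "the series" means these compounds.

- compound 1 `Clc1ccc(-c2nn(-c3ccccc3)cc2-c2nc3ccccc3[nH]2)cc1`: 1650 nM
- compound 2 `Cc1ccc2[nH]c(-c3cn(-c4ccccc4)nc3-c3ccc(Cl)cc3)nc2c1`: 5360 nM

In a functional assay on HeLa cells (Homo sapiens) for antiproliferative activity, read by MTT assay, with a stated time of 48 h (on this read-out lower numbers stand for stronger inhibition and higher numbers for weaker inhibition), compound 2 gives the higher of the two numbers, 5360 nM, so it is the weaker inhibitor. Compound 3 `O=C(OCc1ccccc1)c1ccc2[nH]c(-c3cn(-c4ccccc4)nc3-c3ccc(Cl)cc3)nc2c1` carries benzyloxycarbonyl in place of methyl on an aromatic carbon. For the measured compounds named here, only one measured step bears on this: a 3.2-fold higher number from compound 1 to compound 2 (0.51 log units; beyond the scatter), with methyl in place of hydrogen. That modest step involves a much smaller group and gives no firm direction here, so no shift beyond the scatter is expected in this assay. The expected step is a 1.3-fold lower number from compound 2 to compound 3 (0.13 log units; within the scatter). For compound 3 the estimated value is 4000 nM, with an expected range of 1000 nM to 16000 nM.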

Compound 3, half-maximal inhibitory concentration: 8130 nM
Compound 3: the middle estimate sits 2.0-fold (0.31 log units) below what was measured; low and high end bracket the measured number.
By their numbers in this assay, from the lowest: compound 1; then compounds 2 and 3 (each within the scatter of the next).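

In this assay, swapping methyl for the far larger benzyloxycarbonyl on this aromatic carbon makes no difference beyond the scatter: a 1.5-fold higher number from compound 2 to compound 3 (0.18 log units; within the scatter). Set against hydrogen at the same place, the ester does count: a 4.9-fold higher number from compound 1 to compound 3 (0.69 log units; beyond the scatter). Both groups therefore give higher numbers than hydrogen, while group size makes no clear difference between them, and nothing available here explains why. From the compounds shown here alone, whether a carboxylic acid or an amine on this carbon would bring the number back towards that of compound 1 stays open.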